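The source may hold more compounds than are shown below. What is called first, only, known or untested is meant among the compounds shown, and "the series" means these compounds.

In a functional assay on SGC-7901 cells (Homo sapiens) for antiproliferative activity, read by MTT assay, with a stated time of 24 h (on this read-out higher numbers stand for weaker inhibition and lower numbers for stronger inhibition), compound 1 `Cc1cccc(NNC(=O)c2ccc(NS(=O)(=O)c3cnc(O)nc3O)cc2)c1` gives > 20000 nM, which is a limit of the assay and not a true number. Among the measured compounds shown here, compound 2 `O=C(NNC(=O)c1ccccc1Cl)c1ccc(NS(=O)(=O)c2cnc(O)nc2O)cc1` gives 3240 nM, the only actual number so far. Moving between these two is an at least 6.1-fold lower number from compound 1 to compound 2 (0.79 log units; beyond the scatter), with (2-chlorophenyl)carbonyl in place of 3-methylphenyl on an amine nitrogen.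

Compound 3 `O=C(NNC(=O)c1ccccc1F)c1ccc(NS(=O)(=O)c2cnc(O)nc2O)cc1` keeps the structure of compound 2 except for one small change: fluoro in place of chloro on an aromatic carbon, with fluoro in place of chloro on an aromatic carbon, ortho to a large group. For the measured compounds named here, the single measured step, an at least 6.1-fold lower number from compound 1 to compound 2 (0.79 log units; beyond the scatter), exchanged a whole group, so it does not size a swap of one halogen for another. Only a small change is therefore expected in this assay, in no firm direction and probably within the scatter. The expected change is a 1.1-fold higher number from compound 2 to compound 3 (0.03 log units; within the scatter). For compound 3 the estimate is 3500 nM, with an expected range of 1300 nM to 10000 nM.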

Compound 3, half-maximal inhibitory concentration: > 20000 nM
Compound 3: no number, only a limit; the forecaster's own chance of this, stated with the estimate: 8%; middle value at least 5.7-fold (0.75 log units) away from the limit.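

In this assay compound 3 gives > 20000 nM, which is a limit of the assay and not a number. The single atom at this place on the ring therefore counts: fluoro in place of chloro gives an at least 6.1-fold higher number from compound 2 to compound 3 (0.79 log units; beyond the scatter), a swap of one heavy atom that the earlier exchange of a whole group could not reveal. This step gives only a minimum size, and the step from compound 1 to compound 3 cannot be read, because the values involved end at a limit: the limit of > 20000 nM in this assay, at which 2 of the 3 values shown sit.

Still open, from the compounds shown here alone, is whether the activity belongs to chloro alone or would also come with a bromo or a methyl group at this place. Also open, going by these compounds, is whether a second chloro on the same ring would lower the number further.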